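A Fluorine for a Hydrogen on a Trisphosphate Ring

A few compounds are considered here, and "the series" means these few. Any claim that something is new, unique, unknown or untested is made for them only; others in the source may bear on it.

Two compounds have been measured so far:
Compound 1, `O=P(O)(O)O[C@@H]1CC[C@@H](OP(=O)(O)O)[C@H](OP(=O)(O)O)C1`, gives 3900 nM.
Compound 2, `O=P(O)(O)O[C@@H]1[C@@H](O)[C@@H](O)[C@@H](OP(=O)(O)O)C[C@H]1OP(=O)(O)O`, gives 1000 nM.

Both numbers come from an assay on adrenal cortex for binding affinity to inositol 1,4,5-trisphosphate-gated calcium channel ITPR3 (Bos taurus), using microsomes; on this read-out lower numbers stand for stronger inhibition and higher numbers for weaker inhibition. Of the two, compound 2 holds the lower number, and compound 1 sits at a clearly higher one, a gap that lies beyond the usual scatter of such measurements. Compound 2 therefore stands as the stronger binder of the pair.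

Compound 3, `O=P(O)(O)O[C@@H]1[C@H](O)[C@H](O)[C@@H](OP(=O)(O)O)[C@H](OP(=O)(O)O)[C@H]1F`, has not yet been measured. It differs from compound 2 by fluoro in place of hydrogen on a saturated ring carbon, in words: fluoro in place of hydrogen on a saturated ring carbon. For the measured compounds named here, the phosphate and hydroxy groups of compound 2 stay where they are; only a single ring hydrogen is exchanged.

Going by the values given here, no measured pair shows what this exchange does, so the expectation rests on compound 2 alone. The step from compound 2 to compound 3 is expected to be no change at the digits printed from compound 2 to compound 3 (within the scatter), no change beyond the scatter. For compound 3 the estimated value in this assay is 1000 nM, with a range from 400 nM to 2500 nM.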

Compound 3, half-maximal inhibitory concentration: 2000 nM
For compound 3 the middle estimate is 2.0-fold (0.30 log units) below the measured one; measured number inside the range.
By their numbers in this assay, from the lowest: compounds 2, 3 and 1 (each within the scatter of the next, the first and the last beyond it).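

In this assay, fluoro in place of hydrogen on a saturated ring carbon gives a 2.0-fold higher number from compound 2 to compound 3 (0.30 log units; within the scatter) and so the two compounds cannot be told apart on this read-out. For the compounds shown here, this is the first reading at this position, on a ring carbon next to two ring atoms that each bear a group of 5 heavy atoms, and it shows that a single fluorine atom can stand there without a change beyond the usual scatter of the measurement. No measurement shown here bears on why the exchange leaves the number within the scatter, so the result stands without an explanation.

The compounds shown give one substitution at one ring carbon, so they leave open whether a methyl group, an amine or a longer chain on that same carbon would also leave the number within the scatter. They also leave open whether fluoro on any other carbon of the ring would give a similar reading, since a single pair of compounds cannot establish a trend across the ring.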